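The source may report more compounds than this note shows. Statements on the series, on what has been measured and on what is new or still open speak of the compounds shown alone.

Measured compounds:
compound 1 `CC(=O)Nc1cccc(Cn2cc(-c3ccc4c(N)n[nH]c4c3)ccc2=O)c1` 55 nM
compound 2 `Nc1n[nH]c2cc(-c3ccc(=O)n(Cc4cccc(F)c4)c3)ccc12` 19 nM

Compound 2 holds the lowest of the two numbers in an assay for inhibition of MAP kinase-interacting serine/threonine-protein kinase 1 (Homo sapiens), read by luminescence and ADP-Glo, with a stated time of 2 h; on this read-out lower numbers stand for stronger inhibition and higher numbers for weaker inhibition; its nearest neighbour is compound 1, separated by a 2.9-fold lower number from compound 1 to compound 2 (0.46 log units; beyond the scatter). Compound 3 `Nc1n[nH]c2cc(-c3ccc(=O)n(Cc4ccccc4)c3)ccc12` is not yet measured. It differs from compound 2 by hydrogen in place of fluoro on an aromatic carbon. Within the data shown here, no measured step involves hydrogen at this carbon, so the step from compound 1 to compound 2 does not bear directly on it. The step from compound 2 to compound 3 is therefore expected to be small, likely within the scatter, as a 1.3-fold higher number from compound 2 to compound 3 (0.12 log units; within the scatter). Compound 3 is estimated at 25 nM, between 10 nM and 65 nM.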

Compound 3, half-maximal inhibitory concentration: 79 nM
The estimate for compound 3 lay 3.2-fold (0.50 log units) below the measured number; measured number outside the range, above it.
By their numbers in this assay, from the lowest: compound 2; then compounds 1 and 3 (each within the scatter of the next).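

In this assay the fluoro on this aromatic carbon matters: going from 3-fluorobenzyl to benzyl gives a step beyond the scatter (a 4.2-fold higher number from compound 2 to compound 3 (0.62 log units; beyond the scatter)). Hydrogen and acetamido at this carbon stay within the scatter of each other (a 1.4-fold higher number from compound 1 to compound 3 (0.16 log units; within the scatter)), so of the three groups only the fluoro stands apart. Nothing available explains this step.

On these data alone, whether chloro, methoxy or an amine at this carbon would match the fluoro remains open. So does whether a fluoro on another carbon of this ring would give a similar number.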